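Sulfur for Selenium on Two Related Cores

The compounds below may be only part of what the source reports. "The series", "measured", "known", "first", "only" and "open" are said of these compounds alone.

compound 1 `C[Se]/C(=N\C(=O)c1cccs1)NC(=O)c1cccs1` — > 100000 nM
compound 2 `CS/C(=N\C(=O)c1cccs1)NC(=O)c1cccs1` — > 100000 nM
compound 3 `C[Se]/C(=N\C(=O)c1cnc2ccccc2c1)NC(=O)c1cnc2ccccc2c1` — 29900 nM

Of the compounds shown here, three have been measured in a functional assay on K562 cells (Homo sapiens) for cytotoxicity, read by MTT assay, with a stated time of 72 h; on this read-out lower numbers stand for stronger inhibition of growth and higher numbers for weaker inhibition of growth. Compound 1 `C[Se]/C(=N\C(=O)c1cccs1)NC(=O)c1cccs1` gives only a limit of the assay, > 100000 nM. Compound 2 `CS/C(=N\C(=O)c1cccs1)NC(=O)c1cccs1` likewise gives only a limit, > 100000 nM. Among the measured compounds shown here, compound 3 `C[Se]/C(=N\C(=O)c1cnc2ccccc2c1)NC(=O)c1cnc2ccccc2c1` is the one compound with a number, 29900 nM. The change from compound 1 to compound 2 is a group of 2 heavy atoms (1 carbon, 1 sulfur; no ring) in place of a group of 2 heavy atoms (1 carbon, 1 selenium; no ring), on a carbon with a double bond to nitrogen; its size is a step that the two limits leave unreadable from compound 1 to compound 2, unreadable since both values sit at the limit of > 100000 nM in this assay, at which 2 of the 3 values shown sit. The difference between the cores of compound 1 and compound 3 is not broken down here. Compound 4 `CS/C(=N\C(=O)c1cnc2ccccc2c1)NC(=O)c1cnc2ccccc2c1` carries the same change on the core of compound 3: a group of 2 heavy atoms (1 carbon, 1 sulfur; no ring) in place of a group of 2 heavy atoms (1 carbon, 1 selenium; no ring), on a carbon with a double bond to nitrogen. For the measured compounds named here, no measured pair shows how large such a step is. Compound 4 is expected to show a 2.0-fold higher number from compound 3 to compound 4 (0.30 log units; within the scatter), resting on compound 3 at 29900 nM alone. Compound 4 is therefore estimated at 60000 nM, between 20000 nM and 150000 nM.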

Compound 4, concentration for total growth inhibition: > 100000 nM
Compound 4: no number, only a limit; the forecaster's own chance of this, stated with the estimate: 40%; at least 1.6-fold (0.22 log units) between middle value and limit.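

In this assay, methylsulfanyl in place of the selenium-bearing group on the core of compound 3 gives an at least 3.3-fold higher number from compound 3 to compound 4 (0.52 log units; beyond the scatter), a step beyond the scatter on this one core. The same change on the core of compound 1 cannot be read, so the series does not show that the step carries from one core to another. The step on the core of compound 3 also has only a lower bound, not a size, and most values offer no number to compare: the limit of > 100000 nM in this assay, at which 3 of the 4 values shown sit.

The compounds shown leave open whether the step would appear on further cores. They also leave open how an amine or a longer chain on the carbon with a double bond to nitrogen would compare with the selenium-bearing group.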